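Cyano in Place of 1H-1,2,4-triazol-1-yl: Clearance Outlook

The source may hold more compounds than are shown below. What is called first, only, known or untested is meant among the compounds shown, and "the series" means these compounds.

Measured compounds:
compound 1 `CNc1nc(NC(C#N)(C2CC2)C2CC2)nc(-n2cncn2)n1`: 3.7 mL/min/kg
compound 2 `CNc1nc(NC2(C#N)CCCCC2)nc(-n2cncn2)n1`: 52 mL/min/kg

For the measured compounds named here, in an ADME assay on microsomes from liver (Rattus norvegicus) for metabolic stability (on this read-out higher numbers stand for fast clearance and lower numbers for slow clearance), compound 2 gives 52 mL/min/kg, the higher of the two numbers known so far. Compound 1, in the same assay, gives 3.7 mL/min/kg, and the gap between the two lies beyond the usual scatter. Compound 3 `CNc1nc(C#N)nc(NC2(C#N)CCCCC2)n1` is the next compound; it differs from compound 2 in one place: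

cyano in place of 1H-1,2,4-triazol-1-yl on an aromatic carbon

Going by the values given here, no measured pair shows this change, so there is no step to lean on. The account expects the step of a 1.3-fold lower number from compound 2 to compound 3 (0.11 log units; within the scatter) for compound 3 to stay within the scatter, with no clear direction. Compound 3 is therefore estimated at 40 mL/min/kg in this assay, within a range from 15 mL/min/kg to 110 mL/min/kg.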

Compound 3, clearance: 122 mL/min/kg
For compound 3 the middle estimate is 3.1-fold (0.48 log units) below the measured one; the whole stated range lies below it.
By their numbers in this assay, from the lowest: compound 1; then compound 2; then compound 3.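

In this assay, this position proves not to be indifferent to its substituent: cyano in place of 1H-1,2,4-triazol-1-yl on an aromatic carbon gives a 2.3-fold higher number from compound 2 to compound 3 (0.37 log units; beyond the scatter) with the rest of the molecule unchanged. The step is modest but points towards faster clearance, so removing the triazole ring brings no gain here. Nothing measured on these compounds accounts for the step. On these data alone, whether the same change acts alike on the core of compound 1 stays open. So does how an amine or a methoxy group would read at this position.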